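Amide acyl swap on the tricyclic core: compound 3 to compound 4

This account rests on a few compounds, and the source may have more. Where it says the series, first, only, none or still open, it means among the compounds named here.

Measured so far:
Compound 1 `CCCCNc1nc(N)nc2c1CN(C)CC2` gives 0.03 uM in an assay on HEK293 cells for agonist activity at Toll-like receptor 8 (Homo sapiens), read by a luciferase reporter, with a stated time of 6 h; a higher number here means that more compound is needed for the effect, a lower number that less compound is needed.
Compound 2 `CCCCNc1nc(N)nc2c1CN(Cc1ccccc1Cl)CC2` gives 0.05 uM in this assay.
Compound 3 `CCCCNc1nc(N)nc2c1CN(C(=O)C1CCC1)CC2` gives 0.4 uM in this assay.

Compound 3 stands at the highest number of the three: the steps of a 13-fold higher number from compound 1 to compound 3 (1.12 log units; beyond the scatter) and an 8.0-fold higher number from compound 2 to compound 3 (0.90 log units; beyond the scatter) both lie beyond the scatter, while a 1.7-fold higher number from compound 1 to compound 2 (0.22 log units; within the scatter) lies within it. Compound 4 `CCCCNc1nc(N)nc2c1CN(C(=O)c1csc(N)n1)CC2` differs from compound 3 by 2-amino-1,3-thiazol-4-yl in place of cyclobutyl on a carbonyl carbon. Both measured steps that end at compound 3 exchange the whole group on the ring nitrogen for cyclobutylcarbonyl; neither alters what sits on the carbonyl carbon itself, so the shown data give no measured step for this exchange. The expected step of a 1.3-fold lower number from compound 3 to compound 4 (0.12 log units; within the scatter) is therefore small, with no direction favoured beyond the scatter. Compound 4 is estimated at 0.3 uM, within 0.08 uM to 1.5 uM.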

Compound 4, minimum effective concentration: 6.9 uM
Compound 4: middle estimate off by 23-fold (1.36 log units), on the low side, and the stated range ends below it.
By their numbers in this assay, from the lowest: compounds 1 and 2 (each within the scatter of the next); then compound 3; then compound 4.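

In this assay, what sits on the carbonyl carbon matters on its own: with the carbonyl kept, 2-amino-1,3-thiazol-4-yl in place of cyclobutyl gives a 17-fold higher number from compound 3 to compound 4 (1.24 log units; beyond the scatter). Against the groups without a carbonyl on the ring nitrogen, the exchange to (2-amino-1,3-thiazol-4-yl)carbonyl gives a 140-fold higher number from compound 2 to compound 4 (2.14 log units; beyond the scatter) and a 230-fold higher number from compound 1 to compound 4 (2.36 log units; beyond the scatter). No measured evidence accounts for the size of these steps. On these data alone, whether a plain phenyl on the carbonyl carbon, or the 1,3-thiazol-4-yl ring without its amine, would stay close to compound 3 or to compound 4 remains open.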